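This account rests on a few compounds, and the source may have more. Where it says the series, first, only, none or still open, it means among the compounds named here.

Compound 1, `CCOC1=C(/C(C)=N/OCC(=O)Nc2ccc(F)c(Cl)c2)N(C)S(=O)(=O)c2ccccc21`, reaches in a functional assay on THP-1 cells (Homo sapiens) for inhibition, read by ELISA, with stated times of 2 h and 48 h (a lower number here means a stronger inhibitor, a higher number a weaker inhibitor), only the limit > 20000 nM.
Compound 2, `C/C(=N\OCC(=O)Nc1ccccc1)C1=C(O)c2ccccc2S(=O)(=O)N1C`, reaches in this assay only the limit > 20000 nM.
Compound 3, `COc1ccc(NC(=O)CO/N=C(\C)C2=C(O)c3ccccc3S(=O)(=O)N2C)cc1`, reaches in this assay only the limit > 20000 nM.

Compound 3 therefore stands where every measured compound stands: at a limit, with no number to place it. Compound 4 is `C/C(=N\OCC(=O)Nc1ccc(F)c(Cl)c1)C1=C(O)c2ccccc2S(=O)(=O)N1C`. It differs from compound 3 in one place: 3-chloro-4-fluorophenyl in place of 4-methoxyphenyl on an amide-type nitrogen. For the measured compounds named here, the only measured step, a step that the two limits leave unreadable from compound 2 to compound 3, has limits at both ends and so gives no size. The group that enters here is already carried by compound 1, which also sits at the limit, as the limit of > 20000 nM in this assay, at which 3 of the 3 values shown sit, shows for all three values. No step beyond the scatter can be read in this assay, so compound 4 is expected to sit at the limit too, the estimated step that the limit leaves unreadable from compound 3 to compound 4 meaning no readable change. The estimate for compound 4 is 30000 nM, in the range 10000 nM to 100000 nM.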

Compound 4, half-maximal inhibitory concentration: > 20000 nM
Compound 4: no number, only a limit; the forecaster's own chance of this, stated with the estimate: 85%; the middle value is on the limit's open side.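

No step can be read among compound 1, compound 2, compound 3 and compound 4, since all four sit at one limit: the limit of > 20000 nM in this assay, at which 4 of the 4 values shown sit.

The compounds shown leave open how they rank beyond that limit, and which change, if any, would give a readable number in this assay.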